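Adding a second chloro to compound 2's fused core

The compounds below may be only part of what the source reports. "The series", "measured", "known", "first", "only" and "open" are said of these compounds alone.

Measured compounds:
compound 1 `ClCc1ccc(Cn2cnc3c(Cl)ncnc32)cc1` — in a functional assay on HCT-116 cells (Homo sapiens) for cytotoxicity, read by sulforhodamine B assay, with a stated time of 48 h (on this read-out lower numbers stand for stronger inhibition of growth and higher numbers for weaker inhibition of growth), compound 1 gives 2450 nM
compound 2 `ClCc1cccc(Cn2cnc3ncnc(Cl)c32)c1` — compound 2 gives 5240 nM
compound 3 `ClCc1ccc(Cn2cnc3c(Cl)nc(Cl)nc32)cc1` — compound 3 gives 3630 nM

Among these three, compound 2 carries the highest number. Compound 1 sits lower by a gap beyond the usual scatter, whereas compound 3 lies within the scatter of compound 2, so no order between those two can be claimed.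

Compound 4 `ClCc1cccc(Cn2cnc3nc(Cl)nc(Cl)c32)c1` differs from compound 2 in one place: chloro in place of hydrogen on an aromatic carbon. The same change has been measured once, on the related pair: a 1.5-fold higher number from compound 1 to compound 3 (0.17 log units; within the scatter), a shift within the scatter. On that basis, no step beyond the scatter is expected from compound 2 to compound 4, and the estimated step is a 1.2-fold higher number from compound 2 to compound 4 (0.09 log units; within the scatter). Compound 4 is therefore expected near 6500 nM, with a range from 3300 nM to 13000 nM.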

Compound 4, concentration for total growth inhibition: 1990 nM
The estimate for compound 4 lay 3.3-fold (0.51 log units) above the measured number, and the stated range ends above it.
By their numbers in this assay, from the lowest: compounds 4, 1, 3 and 2 (each within the scatter of the next, the first and the last beyond it).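

Here the change gives a 2.6-fold lower number from compound 2 to compound 4 (0.42 log units; beyond the scatter), so chloro in place of hydrogen at this position, between two ring nitrogen atoms, can shift the number beyond the scatter, which the earlier pair did not show. The change also does not carry a fixed effect from one core to another: the same change on two cores in this assay, a 1.5-fold higher number (0.17 log units; within the scatter) from compound 1 to compound 3 and a 2.6-fold lower number (0.42 log units; beyond the scatter) from compound 2 to compound 4, 3.9-fold (0.59 log units) apart, beyond the scatter of two such steps.

The compounds shown hold only hydrogen or chloro at this position, so what an amine or a methoxy group there would do stays open. Why the two cores respond differently also stays open.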